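This account rests on a few compounds, and the source may have more. Where it says the series, first, only, none or still open, it means among the compounds named here.

Going by the values given here, compound 2 `CCCS(=O)(=O)Nc1ccc(F)c(C(=O)c2n[nH]c3ncc(-c4ccc(O)cc4)cc23)c1F` stands at the lowest of the two numbers so far in an assay for binding affinity to dual specificity mitogen-activated protein kinase kinase 4 (Homo sapiens), read by KINOMEscan, tested at 100 nM; a higher number here means a weaker effect of the compound at the concentration tested, a lower number a stronger effect; in that assay compound 2 gives 0.75%. Its nearest neighbour is compound 1 `CCCS(=O)(=O)Nc1ccc(F)c(C(=O)c2n[nH]c3ncc(-c4cccc(OC)c4)cc23)c1F`, which in this assay gives 6.3%. Among the compounds with values here, the one measured step, a number 5.6 percentage points lower from compound 1 to compound 2 (within the scatter), changes the aryl group on the shared core and stays within the scatter, so both measured compounds sit at low activity percentages. Compound 3 `CCCS(=O)(=O)Nc1ccc(F)c(C(=O)c2n[nH]c3ncc(-c4cccc(N)c4)cc23)c1F` differs from compound 2 by 3-aminophenyl in place of 4-hydroxyphenyl on an aromatic carbon. This change touches the same aryl group as the measured step, which was within the scatter, so no step beyond the scatter is expected in this assay, and the expected step is a number 2.3 percentage points higher from compound 2 to compound 3 (within the scatter). Compound 3 is therefore expected to give 3% in this assay, with a range from 0.3% to 20%.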

Compound 3, a percentage reported as activity, at one concentration (the size of the read-out at that concentration, not a potency): 1.6%
Compound 3: the middle estimate sits 1.4 percentage points above what was measured; the range from low to high includes it.
By their numbers in this assay, from the lowest: compounds 2, 3 and 1 (each within the scatter of the next).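

With 3-aminophenyl, the aryl group on the shared core has now been varied a second time in this assay, and the exchange for 4-hydroxyphenyl gives a number 0.9 percentage points higher from compound 2 to compound 3 (within the scatter) without leaving the low range of percentages. Amino in place of methoxy on the aromatic carbon gives a number 4.7 percentage points lower from compound 1 to compound 3 (within the scatter) and so also stays within the scatter, which means that compound 1, compound 2 and compound 3 cannot be told apart here, whether the aryl group carries a methoxy, a hydroxy or an amino group. Nothing shown explains why these three groups read alike.

The compounds shown leave open whether an unsubstituted phenyl, a 4-aminophenyl or a carboxylic acid on the aryl ring would also stay in this low range. They also leave open whether a longer chain on the sulfonamide in place of propyl would change the reading.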